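This account rests on a few compounds, and the source may have more. Where it says the series, first, only, none or still open, it means among the compounds named here.

Measured compounds in a physicochemical assay for solubility, with a stated time of 18 h, at pH 7.4; on this read-out higher numbers stand for higher solubility and lower numbers for lower solubility:
- compound 1 `c1ccc(Oc2ccc3c(NCCCNCc4ccco4)ccnc3c2)cc1`: 14500 nM
- compound 2 `Fc1ccc(Cc2ccc3c(NCCCNCc4ccco4)ccnc3c2)c(Cl)c1`: 4200 nM
- compound 3 `COc1ccc(Oc2ccc3c(NCCCNCc4ccco4)ccnc3c2)cc1`: 14500 nM

Compound 3 stands level with compound 1 at the digits recorded; together the two give the highest numbers of the three, and compound 2 sits furthest from compound 3 (a 3.5-fold higher number from compound 2 to compound 3 (0.54 log units; beyond the scatter)). Within the series no change at the digits printed from compound 1 to compound 3 (within the scatter), so the methoxy group on the phenoxy ring is not resolved in this assay.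

Compound 4 `c1coc(CNCCCNc2ccnc3cc(-c4cccc5ccccc45)ccc23)c1` is not yet measured. It differs from compound 3 in one place: naphthalen-1-yl in place of 4-methoxyphenoxy on an aromatic carbon.

The step that bears on this change is the one in which the oxygen-linked aryl group of compound 1 gave way to a directly attached ring in compound 2 (a 3.5-fold lower number from compound 1 to compound 2 (0.54 log units; beyond the scatter)). The change from compound 3 to compound 4 likewise removes the oxygen-linked 4-methoxyphenoxy group and brings in a directly attached hydrocarbon ring system, here with two fused aromatic rings and no acceptors counted. On that basis a lower number is expected for compound 4 in this assay, of at least the size seen in that step and possibly larger, and the expected step is a 5.8-fold lower number from compound 3 to compound 4 (0.76 log units; beyond the scatter). The estimate for compound 4 is 2500 nM, with a range from 800 nM to 8000 nM.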

Compound 4, solubility: 32000 nM
Estimate against measurement, compound 4: 13-fold (1.11 log units) below; measured number above the stated range.
By their numbers in this assay, from the lowest: compound 2; then compounds 1 and 3 (each within the scatter of the next); then compound 4.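

In this assay, this aromatic carbon accepts naphthalen-1-yl with a gain rather than a loss: the change gives a 2.2-fold higher number from compound 3 to compound 4 (0.34 log units; beyond the scatter) and, against the unsubstituted phenoxy group, a 2.2-fold higher number from compound 1 to compound 4 (0.34 log units; beyond the scatter) in the same notes, which places compound 4 highest of the four. The earlier compounds shown here held only one replacement for the oxygen-linked aryl groups, and it lowered the number, whereas the comparison with that replacement now shows a 7.6-fold higher number from compound 2 to compound 4 (0.88 log units; beyond the scatter) and the loss of an oxygen-linked group no longer tracks with a lower number, with compound 2 alone going against the rise. The entering group counts 0 hydrogen-bond acceptors against 2 for the leaving group, so a drop in that count accompanies a higher number here, though no measurement on these compounds accounts for the rise.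

As far as these compounds go, whether the gain belongs to the fused pair of rings or to direct attachment remains open, and a single phenyl ring or naphthalen-2-yl at this carbon would separate the two. From the compounds shown here alone, how an amine or a carboxylic acid at this position, or a longer chain on the shared core, would read remains open as well.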